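The source may hold more compounds than are shown below. What is called first, only, known or untested is meant among the compounds shown, and "the series" means these compounds.

Compound 1 `C/C(=C\CC/C(C)=C/CC[C@@H]1[C@@]2(C)CCC(=O)C(C)(C)[C@H]2CC[C@@]1(C)O)CC/C=C(\C)C(=O)OCc1cn(-c2ccc(F)c(Cl)c2)nn1`: > 150000 nM (a limit of the assay)
Compound 2 `C/C(=C\CC/C(C)=C/CC[C@@H]1[C@@]2(C)CCC(=O)C(C)(C)[C@H]2CC[C@@]1(C)O)CC/C=C(\C)C(=O)OCc1cn(-c2ccc(Br)cc2)nn1`: > 150000 nM (a limit of the assay)

In a functional assay on DU-145 cells (Homo sapiens) for antiproliferative activity, read by MTT assay, with a stated time of 48 h (a lower number here means a stronger inhibitor, a higher number a weaker inhibitor), compound 2 gives > 150000 nM, which is a limit and not a number. Compound 1 gives > 150000 nM, which is likewise a limit. Among the measured compounds shown here, compound 2 therefore has no measured potency to stand on, and the only other value shown is also a limit.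

The next compound, compound 3 `C/C(=C\CC/C(C)=C/CC[C@@H]1[C@@]2(C)CCC(=O)C(C)(C)[C@H]2CC[C@@]1(C)O)CC/C=C(\C)C(=O)OCc1cn(-c2ccc(Cl)cc2)nn1`, carries chloro in place of bromo on an aromatic carbon. For the measured compounds named here, the sole measured step that bears on this change is a step that the two limits leave unreadable from compound 1 to compound 2, in which 4-bromophenyl replaces 3-chloro-4-fluorophenyl on an aromatic nitrogen. Because of the limit of > 150000 nM in this assay, at which 2 of the 2 values shown sit, that step offers no size to carry over, so no direction can be assigned, and no change beyond the scatter is expected in this assay.

The expectation rests on compound 2, whose > 150000 nM is a limit. The expected change is a step that the limit leaves unreadable from compound 2 to compound 3. For compound 3 the estimated value is 170000 nM. The expected range for compound 3 runs from 90000 nM to 300000 nM, and a further limit is the likeliest report.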

Compound 3, half-maximal inhibitory concentration: > 150000 nM
Compound 3: a limit, no number; the forecaster's own chance of this, stated with the estimate: 85%; the middle value does not contradict the limit.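

In this assay compound 3 gives > 150000 nM, which is a limit of the assay and not a number. No step among compound 1, compound 2 and compound 3 can be read, because all three rest on the same limit: the limit of > 150000 nM in this assay, at which 3 of the 3 values shown sit.

The compounds shown leave open whether the 4-chlorophenyl, 4-bromophenyl and 3-chloro-4-fluorophenyl groups differ at all, and where the true potency of each compound lies.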